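This account rests on a few compounds, and the source may have more. Where it says the series, first, only, none or still open, it means among the compounds named here.

Measured so far:
- compound 1, `Cc1noc(C)c1-c1cccc(COc2ccc(S(=O)(=O)CC(=O)O)cc2)c1`: 269 nM
- compound 2, `Cc1ccc(-c2c(C)noc2C)cc1COc1ccc(S(=O)(=O)CC(=O)O)cc1`: 427 nM

Among the compounds with values here, compound 2 gives the highest of the two numbers so far in a functional assay on CHO cells for agonist activity at Free fatty acid receptor 1 (Homo sapiens), read by FLIPR and calcium flux (a higher number here means that more compound is needed for the effect, a lower number that less compound is needed), though the only measured step is a 1.6-fold higher number from compound 1 to compound 2 (0.20 log units; within the scatter), so the two compounds are not separated beyond the scatter. Compound 3, `Cc1noc(C)c1-c1ccc(Cl)c(COc2ccc(S(=O)(=O)CC(=O)O)cc2)c1`, is unmeasured; it arises from compound 2 by chloro in place of methyl on an aromatic carbon. Within the data shown here, only one measured step exists, the introduction of this same methyl group from compound 1 to compound 2, and that step stayed within the scatter. Nothing measured tells how a chloro group behaves at this carbon. Compound 3 is therefore expected to land close to compound 2, with a step of a 1.2-fold lower number from compound 2 to compound 3 (0.09 log units; within the scatter) in this assay and no clear direction. The estimate for compound 3 is 350 nM, with a range from 150 nM to 900 nM.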

Compound 3, half-maximal effective concentration: 234 nM
Compound 3: middle estimate off by 1.5-fold (0.17 log units), on the high side, and the stated range covers the measured number.
By their numbers in this assay, from the lowest: compounds 3, 1 and 2 (each within the scatter of the next).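

In this assay, chloro is the second group tried in place of hydrogen on this aromatic carbon, ortho to a large group and para to a 3,5-dimethyl-1,2-oxazol-4-yl group, and it gives a 1.1-fold lower number from compound 1 to compound 3 (0.06 log units; within the scatter) and, against methyl, a 1.8-fold lower number from compound 2 to compound 3 (0.26 log units; within the scatter). Hydrogen, methyl and chloro at this carbon are therefore not separated from one another, so swapping among these three groups here has shown no step beyond the scatter. Nothing available bears on what lies behind these numbers.

The compounds shown leave open whether an amine, a methoxy group or a longer chain such as propyl at this carbon would stay within the scatter of these three. They also leave open whether chloro would read the same way on the other carbons of this ring.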